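Shortening the linker of an iodoacetamide-bearing nucleotide

A few compounds are considered here, and "the series" means these few. Any claim that something is new, unique, unknown or untested is made for them only; others in the source may bear on it.

Measured so far:
Compound 1 `O=C(CI)NCCCCCCCCNc1ncnc2c1ncn2[C@@H]1O[C@H](COP(=O)(O)OP(=O)(O)OP(=O)(O)O)[C@@H](O)[C@H]1O`: 35%
Compound 2 `O=C(CI)NCCCCC(=O)NCCCCCCNc1ncnc2c1ncn2[C@@H]1O[C@H](COP(=O)(O)OP(=O)(O)OP(=O)(O)O)[C@@H](O)[C@H]1O`: 0%

In an assay on isolated protein for inhibition of hexokinase-1 (Rattus norvegicus), with a stated time of 6 h, tested at 10 mM (a higher number here means more inhibition at the concentration tested (going by the name of the read-out), a lower number less inhibition), compound 1 gives 35%, the higher of the two numbers measured, with compound 2 giving 0%. Going by the values given here, the one measured step that bears on the chain, a number 35 percentage points lower from compound 1 to compound 2 (beyond the scatter), shows how sharply inhibition can fall when the chain between the shared core and the iodoacetamide is altered. Compound 3 `O=C(CI)NCCNc1ncnc2c1ncn2[C@@H]1O[C@H](COP(=O)(O)OP(=O)(O)OP(=O)(O)O)[C@@H](O)[C@H]1O` differs from compound 1 by ((iodomethyl)carbonyl)amino in place of 6-(((iodomethyl)carbonyl)amino)hexyl on a saturated chain carbon, two bonds along the chain from a nitrogen on an aromatic ring. The same sensitivity is expected here; the expected step is a number 20 percentage points lower from compound 1 to compound 3 (beyond the scatter). Compound 3 is therefore estimated to give 15%, within 0% to 40%.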

Compound 3, a percentage reported as inhibition, at one concentration (the size of the read-out at that concentration, not a potency): 0%
Compound 3: middle estimate off by 15 percentage points, on the high side; measured number inside the range.
By their numbers in this assay, from the lowest: compounds 2 and 3 (each within the scatter of the next); then compound 1.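

Cutting 6-(((iodomethyl)carbonyl)amino)hexyl back to ((iodomethyl)carbonyl)amino gives a number 35 percentage points lower from compound 1 to compound 3 (beyond the scatter) in this assay. Inhibition at this position is therefore lost on removing chain as well as on the change to the larger group in compound 2, so among these three compounds only the chain of compound 1 retains a measurable reading. No evidence here accounts for this loss. On these data alone, whether a butyl or a hexyl chain carrying the same ((iodomethyl)carbonyl)amino group retains inhibition remains open, and so does the effect of a longer unbroken carbon chain.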